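Ring Exchange at the Chain End of Compound 2

The compounds below may be only part of what the source reports. "The series", "measured", "known", "first", "only" and "open" are said of these compounds alone.

Compound 1, `CN/C(=N/C#N)NCCCCc1nc[nH]c1C`, gives < 5 in a functional assay on Sf9 cells for antagonist activity at histamine H2 receptor (Homo sapiens), read by scintillation counting and GTPgammaS binding, with a stated time of 90 min (on this read-out higher numbers stand for higher potency (the scale is a negative logarithm) and lower numbers for lower potency), which is a limit of the assay and not a number.
Compound 2, `Cc1[nH]cnc1CCCCN/C(=N\C#N)NCCSc1ccccc1`, gives 5.36.
Compound 3, `CN/C(=N/C#N)NCCCCCn1ccnc1C`, gives < 5, again a limit of the assay rather than a number.

Within the data shown here, compound 2 therefore holds the only number in the set; the other two values are limits, as the limit of < 5 in this assay, at which 2 of the 3 values shown sit, records. Among the measured compounds shown here, the one measured step, a number at least 0.36 log units higher from compound 1 to compound 2 (beyond the scatter), concerns the (phenylsulfanyl)methyl group, and that group is carried over unchanged into compound 4, `N#C/N=C(\NCCCCc1nc(N)n[nH]1)NCCSc1ccccc1`. What changes instead is the ring at the far end of the chain: 3-amino-1H-1,2,4-triazol-5-yl in place of 5-methyl-1H-imidazol-4-yl on a saturated chain carbon, four bonds along the chain from an amine nitrogen. No measured pair differs in this ring, so nothing among the shown steps bears on the change directly, and the scale of its effect is not settled by these data. The expectation therefore rests on compound 2 alone, with the step of a number 0.06 log units lower from compound 2 to compound 4 (within the scatter) expected to stay within the scatter. Compound 4 is estimated at 5.3, with a range from 4.6 to 6, and with a fair chance that only a limit is reported.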

Compound 4, negative logarithm of the antagonist equilibrium constant: < 5
Compound 4: only a limit was reported; the forecaster's own chance of this, stated with the estimate: 35%; middle value at least 0.30 log units away from the limit.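

In this assay compound 4 gives < 5, a limit of the assay and not a number. Among these compounds, replacing 5-methyl-1H-imidazol-4-yl with 3-amino-1H-1,2,4-triazol-5-yl gives a number at least 0.36 log units lower from compound 2 to compound 4 (beyond the scatter), the first direct reading of a ring exchange on a saturated chain carbon, four bonds along the chain from an amine nitrogen, and it shows that the two rings are not interchangeable there while the (phenylsulfanyl)methyl group stays the same. The earlier step credited the measured number to that group alone, but the group now proves insufficient by itself to keep a compound clear of the limit, which has become the commonest result in the set: the limit of < 5 in this assay, at which 3 of the 4 values shown sit.

The true size of the step remains unknown, since only its minimum can be read, and the compounds shown do not separate the effect of the amine on the ring from that of the change from imidazole to triazole. They also leave open how a 1H-1,2,4-triazole without the amine, or an imidazole carrying an amine in place of the methyl, would read at this position.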